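Swapping Ethyl for Methoxy: A Step Expected Within Scatter

This account rests on a few compounds, and the source may have more. Where it says the series, first, only, none or still open, it means among the compounds named here.

Compound 1 `CCc1ccc(/C=N/NC(N)=S)cc1`: > 100%
Compound 2 `CCc1ccccc1/C=N/NC(N)=S`: > 100%

In a functional assay on B16 cells (Mus musculus) for inhibition, tested at 10 uM (a lower number here means less inhibition, a higher number more inhibition at the concentration tested (going by the name of the read-out)), compound 1 gives > 100%, a limit of the assay rather than a number. Compound 2 gives > 100%, again a limit. Compound 2 thus stands at the limit of > 100% in this assay, at which 2 of the 2 values shown sit, alongside compound 1, at the top of what this assay reports. Compound 3 `COc1ccccc1/C=N/NC(N)=S` is not yet measured; it differs from compound 2 by methoxy in place of ethyl on an aromatic carbon. Among the measured compounds shown here, with no measured step to guide the size, a step of a number no higher from compound 2 to compound 3 (the limit leaves the size open) in this assay is expected, nothing beyond the scatter. Compound 3 is therefore estimated at 100%, between 70% and 100%.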

Compound 3, a percentage reported as inhibition, at one concentration (the size of the read-out at that concentration, not a potency): 52%
Compound 3: the middle estimate sits 48 percentage points above what was measured; measured number below the stated range.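

In this assay, among the compounds shown here, the earlier compounds sat at the top of what the assay reports, so they gave no sign that the group at this aromatic carbon matters. Methoxy in place of ethyl gives a number at least 48 percentage points lower from compound 2 to compound 3 (beyond the scatter), although both groups have the same heavy-atom count and differ by an oxygen in place of a carbon. The size of this step is only a minimum, because compound 2 sits at a limit of the assay: the limit of > 100% in this assay, at which 2 of the 3 values shown sit.

On these data alone, what a hydroxyl group or an amine would do at this place stays open. So does whether a longer chain such as propoxy would behave like methoxy.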